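A few compounds are considered here, and "the series" means these few. Any claim that something is new, unique, unknown or untested is made for them only; others in the source may bear on it.

Measured so far in a functional assay on C6 cells (Rattus norvegicus) for cytotoxicity, read by MTT assay, with a stated time of 24 h, tested at 50 ug/mL; a lower number here means a stronger effect, a higher number a weaker effect of the compound at the concentration tested:
compound 1 `O=C(CSc1ncccn1)N/N=c1/scc(-c2ccc(F)cc2)n1-c1ccccc1` gives 55.5%
compound 2 `COc1ccc(-c2cs/c(=N/NC(=O)CSc3ncccn3)n2-c2ccccc2)cc1` gives 66.5%

Going by the values given here, compound 2 stands highest of the two numbers; the only step is a number 11 percentage points higher from compound 1 to compound 2 (beyond the scatter). Compound 3 `Cc1ccc(-c2cs/c(=N/NC(=O)CSc3ncccn3)n2-c2ccccc2)cc1` differs from compound 2 by methyl in place of methoxy on an aromatic carbon. Among the compounds with values here, no measured step touches this change; the single step, methoxy in place of fluoro, speaks to a different exchange at the same aromatic carbon, so it is a weak guide only. The step from compound 2 to compound 3 is therefore expected to stay within the scatter, a number 4.5 percentage points lower from compound 2 to compound 3 (within the scatter). Compound 3 is estimated at 62%, range 48% to 76%.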

Compound 3, a percentage reported as activity, at one concentration (the size of the read-out at that concentration, not a potency): 64.4%
The estimate for compound 3 lay 2.4 percentage points below the measured number; the range from low to high includes it.
By their numbers in this assay, from the lowest: compounds 1, 3 and 2 (each within the scatter of the next, the first and the last beyond it).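

In this assay the change from 4-methoxyphenyl to 4-methylphenyl gives a number 2.1 percentage points lower from compound 2 to compound 3 (within the scatter) so these two groups are not separated on this aromatic carbon. Methyl in place of fluoro gives a number 8.9 percentage points higher from compound 1 to compound 3 (within the scatter) and so, unlike methoxy in place of fluoro, does not clear the scatter, which leaves compound 3 unresolved from both compound 1 and compound 2. Nothing on hand offers an explanation for these steps.

From the compounds shown here alone, whether an amine or a carboxylic acid on this aromatic carbon would give a step beyond the scatter stays open. So does the effect of changes elsewhere on the shared core.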